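The compounds below may be only part of what the source reports. "The series", "measured", "known", "first", "only" and "open" are said of these compounds alone.

Compound 1 `N[C@@H]1CCCN(c2cc(Nc3ccccc3Cl)n3nccc3n2)C1` was tested in an assay on isolated protein for inhibition of Dipeptidyl peptidase 9 (Homo sapiens); on this read-out lower numbers stand for stronger inhibition and higher numbers for weaker inhibition. In this assay compound 1 gives > 100000 nM, which is a limit of the assay rather than a number. Compound 2 `N[C@@H]1CCCN(c2cc(NCc3ccccc3)n3nccc3n2)C1` gives > 100000 nM, also a limit. Compound 3 `Cc1ccc(Nc2cc(N3CCC[C@@H](N)C3)nc3ccnn23)c(N)c1` gives > 100000 nM, again a limit. All three sit at the limit of > 100000 nM in this assay, at which 3 of the 3 values shown sit, so the steps a step that the two limits leave unreadable from compound 1 to compound 2, a step that the two limits leave unreadable from compound 1 to compound 3 and a step that the two limits leave unreadable from compound 2 to compound 3 cannot be read in size. Compound 4 `N[C@@H]1CCCN(c2cc(NCc3ccc(O)cc3)n3nccc3n2)C1` differs from compound 1 by 4-hydroxybenzyl in place of 2-chlorophenyl on a nitrogen on an aromatic ring. The measured steps change the same group on the shared core and so bear on this change, yet none of them reveals a size or a direction. The estimate for compound 4 in this assay is therefore 100000 nM, within 30000 nM to 300000 nM. That corresponds to an expected step of a number no higher from compound 1 to compound 4 (the limit leaves the size open), none beyond the scatter.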

Compound 4, half-maximal inhibitory concentration: > 50000 nM
Compound 4: only a limit was reported (the forecaster's own chance of this, stated with the estimate: 85%); the middle value is on the limit's open side.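

Compound 4 reports only a limit, as do compound 1, compound 2 and compound 3, so none of its steps to them can be read in size. The compounds shown leave open whether any group on this nitrogen gives a measurable value in this assay.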